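The source may report more compounds than this note shows. Statements on the series, on what has been measured and on what is new or still open speak of the compounds shown alone.

Measured so far:
- compound 1, `O=c1cc(Cn2cc(-c3cc(F)cc(F)c3)nn2)c2ccc(O)cc2o1`: 27600 nM 
- compound 2, `CCCC1CCC(c2ccc(-c3cn(Cc4cc(=O)oc5cc(O)ccc45)nn3)cc2)CC1`: 34300 nM 
- compound 3, `Cc1ccc2nc(-c3ccc(NCc4cn(Cc5cc(=O)oc6cc(O)ccc56)nn4)cc3)sc2c1`: 7260 nM 

All three values come from a functional assay on HeLa cells (Homo sapiens) for inhibition, read by MTT assay, with a stated time of 72 h; on this read-out lower numbers stand for stronger inhibition and higher numbers for weaker inhibition. Compound 3 gives the lowest number of the three; its gap to compound 1 and its gap to compound 2 both lie beyond the scatter, so on these numbers compound 3 is the most potent of the measured set. Going by the values given here, no pair among the measured compounds differs in a single place, so no step in this assay has been measured directly.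

Compound 4, `Cc1ccc2c(Cn3cc(CNc4ccc(-c5nc6ccc(C)cc6s5)cc4)nn3)cc(=O)oc2c1`, differs from compound 3 in one place: methyl in place of hydroxy on an aromatic carbon. Among the compounds with values here, no measured pair shows the effect of this exchange on the shared core, so any expectation rests on the change itself rather than on a measured step.

The expectation is a small loss in this assay, a step no larger than roughly the scatter, with the estimated step from compound 3 to compound 4 being a 1.7-fold higher number from compound 3 to compound 4 (0.22 log units; within the scatter). For compound 4 the estimated value in this assay is 12000 nM, with a range from 4000 nM to 40000 nM.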

Compound 4, half-maximal inhibitory concentration: 51400 nM
Estimate against measurement, compound 4: 4.3-fold (0.63 log units) below; measured number above the stated range.
By their numbers in this assay, from the lowest: compound 3; then compounds 1, 2 and 4 (each within the scatter of the next).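

In this assay, going by these compounds alone, methyl in place of hydroxy on an aromatic carbon of the six-membered carbon-only ring, part of a fused system of two rings, gives a 7.1-fold higher number from compound 3 to compound 4 (0.85 log units; beyond the scatter); this is the first measured step and it lies beyond the scatter. This place on the shared core is therefore not indifferent to the exchange: with the rest of the structure held constant, the hydroxy form carries the lower number, and the exchange removes the hydrogen-bond donor and acceptor counted for the hydroxy, while the methyl counts none. Nothing at hand accounts for the size of this step.

A single pair cannot show whether the step follows from losing the hydroxy or from introducing the methyl, and a methoxy group or an amine at this place would help separate those two readings. Going by these compounds, it also remains open whether the same exchange produces a step of similar size with the side chains of compound 1 and compound 2, since only the side chain shared by compound 3 and compound 4 has been compared here.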